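Acylurea series: replacing pyridin-2-yl with isopropyl, clearance outlook

A few compounds are considered here, and "the series" means these few. Any claim that something is new, unique, unknown or untested is made for them only; others in the source may bear on it.

Measured in an in vitro ADME assay on microsomes from liver (Rattus norvegicus) for metabolic stability, with a stated time of 30 min; on this read-out lower numbers stand for slow clearance and higher numbers for fast clearance:
- compound 1, `COc1ccccc1C(=O)NC(=O)Nc1ccc(-c2ccccc2)c(C(C)C)c1`: < 14 mL.min-1.g-1, a limit of the assay
- compound 2, `COc1ccccc1C(=O)NC(=O)Nc1ccc(-c2ccccn2)c(C(F)(F)F)c1`: 15 mL.min-1.g-1
- compound 3, `COc1ccccc1C(=O)NC(=S)Nc1ccc(N2CCCCC2)c(Cl)c1`: 29 mL.min-1.g-1

Going by the values given here, only two numbers stand in this assay. Compound 2 gives 15 mL.min-1.g-1, and compound 3 gives 29 mL.min-1.g-1; the gap between them lies within the scatter, so no order can be read from them. Among the compounds with values here, for compound 1 the read-out is a limit (the limit of < 14 mL.min-1.g-1 in this assay, at which 1 of the 3 values shown sits), not a number, so it gives no step against either of the others.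

Compound 4, `COc1ccccc1C(=O)NC(=O)Nc1ccc(C(C)C)c(C(F)(F)F)c1`, is the next member. Against compound 2 the change is isopropyl in place of pyridin-2-yl on an aromatic carbon. Within the data shown here, no measured pair shows this change, so its size in this assay is open. Among the measured compounds shown here, with three compounds, one of them a limit, and no steps between them, no pattern can be claimed for the series.

The expectation for compound 4 is a modest rise in clearance from compound 2, a 1.7-fold higher number from compound 2 to compound 4 (0.22 log units; within the scatter), at the edge of the scatter rather than clearly beyond it. Compound 4 is thus estimated at 25 mL.min-1.g-1, within a range from 10 mL.min-1.g-1 to 60 mL.min-1.g-1.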

Compound 4, intrinsic clearance in microsomes in the Rattus norvegicus assay: < 14 mL.min-1.g-1
Compound 4: only a limit was reported (the forecaster's own chance of this, stated with the estimate: 20%); middle value at least 1.7-fold (0.25 log units) away from the limit.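

Going by these compounds alone, this is the first measured pair for isopropyl in place of pyridin-2-yl on this aromatic carbon, and in the Rattus norvegicus assay it gives an at least 1.0-fold lower number from compound 2 to compound 4 (0.02 log units; that floor lies within the scatter), so the pair shows no clearance change that can be read beyond the scatter. Within the data shown here, the same pair separates clearly on another read-out: in a physicochemical assay for solubility (on this read-out higher numbers stand for higher solubility and lower numbers for lower solubility), compound 2 gives 28 ug/mL, and the change brings an at least 28-fold lower number from compound 2 to compound 4 (1.44 log units; beyond the scatter), a large step that no earlier compound could show. On these data alone, in the physicochemical assay compound 4 gives < 1 ug/mL, which is a limit of the assay, so the true size of this step remains unknown.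

A single pair cannot show whether the solubility step follows the departure of pyridin-2-yl or the arrival of isopropyl, and it cannot show whether the same step would appear on another core. A morpholine or a carboxylic acid at this position would test whether a group other than these two can hold clearance near compound 2 while keeping a solubility reading above the limit of the assay.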